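Fluoro-for-hydrogen step in the quinoline urea cytotoxicity series

The compounds below may be only part of what the source reports. "The series", "measured", "known", "first", "only" and "open" are said of these compounds alone.

Measured so far:
Compound 1 `Cc1cc(NC(=O)Nc2ccc([N+](=O)[O-])c(C(F)(F)F)c2)c2ccccc2n1` gives > 25000 nM in an ADME assay on HEK293 cells (Homo sapiens) for cytotoxicity, with a stated time of 72 h (on this read-out lower numbers stand for an effect already at smaller amounts and higher numbers for an effect only at larger amounts of compound), a limit of the assay rather than a number.
Compound 2 `COc1ccc(NC(=O)Nc2cc(C)nc3ccccc23)cc1` gives > 25000 nM in this assay, likewise a limit.
Compound 3 `Cc1cc(NC(=O)Nc2ccc(C(=O)O)cc2)c2ccccc2n1` gives > 25000 nM in this assay, again a limit.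

Compound 2 therefore stands only at a limit, and the two further values shown are limits as well. Within the data shown here, the one single-point step among the measured compounds, a step that the two limits leave unreadable from compound 2 to compound 3, is unreadable in size for the same reason. What the series does show is the limit of > 25000 nM in this assay, at which 3 of the 3 values shown sit.

Compound 4 `COc1ccc(NC(=O)Nc2cc(C)nc3ccccc23)cc1F` differs from compound 2 by fluoro in place of hydrogen on an aromatic carbon, the entering fluoro sitting ortho to the methoxy group and meta to the large group. Among the measured compounds shown here, no measured step resembles this change, and the steps that exist are themselves unreadable; the expectation rests on the limits alone. Compound 4 is expected to give 40000 nM in this assay, with a range of 20000 nM to 100000 nM. The step that the limit leaves unreadable from compound 2 to compound 4 is accordingly expected to be none beyond the scatter, most likely ending at a limit again.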

Compound 4, half-maximal effective concentration: > 25000 nM
Compound 4: a limit, no number; the forecaster's own chance of this, stated with the estimate: 85%; the middle value is on the limit's open side.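

Among these compounds, compound 2 and compound 4 both stand at a limit in this assay, so no step between them can be read: the limit of > 25000 nM in this assay, at which 4 of the 4 values shown sit. The compounds shown leave open where the half-maximal effective concentration of any of them lies, and whether fluoro in place of hydrogen shifts it.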